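A few compounds are considered here, and "the series" means these few. Any claim that something is new, unique, unknown or untested is made for them only; others in the source may bear on it.

Measured compounds: compound 1 `CC1(C)CCC(CN2CCN(c3ccc(C(=O)NS(=O)(=O)c4ccc(NCC5CCOCC5)c([N+](=O)[O-])c4)c(Oc4cnc5[nH]ccc5c4)c3)CC2)=C(c2ccccc2C(F)(F)F)C1` gives 1.7 nM in an assay on isolated protein for displacement of a labelled ligand from Apoptosis regulator Bcl-2 (Homo sapiens), with a stated time of 15 min; on this read-out higher numbers stand for weaker inhibition and lower numbers for stronger inhibition; compound 2 `CC(C)C(=O)N1CCC(CNc2ccc(S(=O)(=O)NC(=O)c3ccc(N4CCN(CC5=C(c6ccc(C(F)(F)F)cc6)CC(C)(C)CC5)CC4)cc3Oc3cnc4[nH]ccc4c3)cc2[N+](=O)[O-])CC1` gives 2.4 nM; compound 3 `CC1(C)CCC(CN2CCN(c3ccc(C(=O)NS(=O)(=O)c4ccc(NC5CCOC5)c([N+](=O)[O-])c4)c(Oc4cnc5[nH]ccc5c4)c3)CC2)=C(c2ccc(C(F)(F)F)cc2)C1` gives 1.9 nM.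

Compound 3 stands second highest of the three numbers, with compound 1 and compound 2 both within the scatter of it. Compound 4 `CC(Oc1ccc(S(=O)(=O)NC(=O)c2ccc(N3CCN(CC4=C(c5ccc(C(F)(F)F)cc5)CC(C)(C)CC4)CC3)cc2Oc2cnc3[nH]ccc3c2)cc1[N+](=O)[O-])C1CCOCC1` is not yet measured. It differs from compound 3 by a group of 9 heavy atoms (7 carbon, 2 oxygen; one six-membered non-aromatic ring with 1 hetero atom) in place of a group of 6 heavy atoms (4 carbon, 1 nitrogen, 1 oxygen; one five-membered non-aromatic ring with 1 hetero atom), on an aromatic carbon, on an aromatic carbon ortho to a nitro group and para to a large group. Among the compounds with values here, the one measured step at that same position, a 1.3-fold lower number from compound 2 to compound 3 (0.10 log units; within the scatter), stayed within the scatter. Within the data shown here, no measured step exchanges an amino link for an ether link, so the expectation rests on that single step alone. Compound 4 is therefore expected to show no step beyond the scatter, a 1.3-fold higher number from compound 3 to compound 4 (0.12 log units; within the scatter). The estimate for compound 4 is 2.5 nM, within 1.2 nM to 6 nM.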

Compound 4, half-maximal inhibitory concentration: 9.2 nM
Compound 4: middle estimate off by 3.7-fold (0.57 log units), on the low side; the measured number lies above the stated range.
By their numbers in this assay, from the lowest: compounds 1, 3 and 2 (each within the scatter of the next); then compound 4.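

In this assay, within the data shown here, the position on the aromatic carbon ortho to a nitro group proves sensitive to this exchange: replacing (oxolan-3-yl)amino with the new group gives a 4.8-fold higher number from compound 3 to compound 4 (0.69 log units; beyond the scatter), the only step here beyond the scatter. The entering group has an oxygen where the leaving group has a nitrogen and 0 hydrogen-bond donors against 1, and its ring is six-membered rather than five-membered, so this single step does not separate these differences. Nothing at hand bears on the cause of this step.

Open, from the compounds shown here alone, is whether the oxygen link or the larger group accounts for the step. Also open, going by these compounds, is how a plain methoxy group or a morpholine ring would read at this position.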